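Halogen Swap in a Cytotoxicity Series

The source may report more compounds than this note shows. Statements on the series, on what has been measured and on what is new or still open speak of the compounds shown alone.

Measured so far:
compound 1, `O=C(N/N=C/c1ccccc1)c1cnccn1`: 100%
compound 2, `O=C(N/N=C/c1ccc(F)cc1)c1cnccn1`: 78%

Of the compounds shown here, two have been measured in an ADME assay on J774 cells (Mus musculus) for cytotoxicity, read by MTT assay, with a stated time of 48 h, tested at 50 ug/mL; a higher number here means a weaker effect of the compound at the concentration tested, a lower number a stronger effect. Among the compounds with values here, compound 1 gives 100%, and compound 2 gives 78%, the lower of the two numbers; the only measured step, a number 22 percentage points lower from compound 1 to compound 2 (beyond the scatter), places compound 2 beyond the scatter from compound 1. The unmeasured compound 3, `O=C(N/N=C/c1ccc(Br)cc1)c1cnccn1`, differs from compound 2 by bromo in place of fluoro on an aromatic carbon. Within the data shown here, no measured step exchanges one halogen for another, so the step from compound 1 to compound 2 is the only guide, and it shows that a halogen at this position can move the number downward by a modest amount. On that basis a step of similar or slightly larger size in the same direction is expected for compound 3, a number 8 percentage points lower from compound 2 to compound 3 (within the scatter), though a step within the scatter cannot be excluded. Compound 3 is therefore estimated at 70%, with a range from 45% to 95%.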

Compound 3, a percentage reported as activity, at one concentration (the size of the read-out at that concentration, not a potency): 100%
Estimate against measurement, compound 3: 30 percentage points below, outside the stated range (above it).
By their numbers in this assay, from the lowest: compound 2; then compounds 1 and 3 (each within the scatter of the next).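

In this assay, the two halogens on this aromatic carbon do not behave alike: a number 22 percentage points higher from compound 2 to compound 3 (beyond the scatter), while no change at the digits printed from compound 1 to compound 3 (within the scatter). The lower number seen earlier for compound 2 therefore does not extend to halogens in general, and among these three compounds it goes with fluoro alone, with compound 3 going against any rule that a halogen at this place lowers the number. Nothing available explains why fluoro and bromo part here.

As far as these compounds go, it remains open whether chloro at the same place would fall with fluoro or with bromo, and what an amine, a methoxy group or a carboxylic acid would do there. The compounds shown also leave open whether fluoro would give a similar step on another carbon of that ring.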